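The source may report more compounds than this note shows. Statements on the series, on what has been measured and on what is new or still open speak of the compounds shown alone.

Measured in an ADME assay on cells (Hepatocyte, Homo sapiens) for metabolic stability, read by LC-MS, tested at 3 uM; on this read-out higher numbers stand for a longer-lived compound and lower numbers for a shorter-lived compound:
Compound 1 `C[C@@H](NC(=O)c1nc(-c2cc(C(F)(F)F)ccn2)nc(O)c1O)C1CCCCC1`: > 4 h, a limit.
Compound 2 `COc1ccnc(-c2nc(O)c(O)c(C(=O)N[C@H](C)C3CCCCC3)n2)c1`: > 4 h, a limit.

Compound 2 has no number on this read-out, only the limit > 4 h. Compound 3 `C[C@@H](NC(=O)c1nc(-c2cc(Cl)ccn2)nc(O)c1O)C1CCCCC1` carries chloro in place of methoxy on an aromatic carbon, meta to a large group and opposite the ring nitrogen: chloro in place of methoxy on an aromatic carbon. For the measured compounds named here, one measured step bears on this change, at the same aromatic carbon: a step that the two limits leave unreadable from compound 1 to compound 2, with methoxy in place of trifluoromethyl. Its size cannot be read. What the series shows is the limit of > 4 h in this assay, at which 2 of the 2 values shown sit. Chloro has not yet been measured here. No step beyond the scatter is expected in this assay, and no direction can be assigned. The expected step is a step that the limit leaves unreadable from compound 2 to compound 3. For compound 3 the estimated half-life is 6 h, with an expected range of 3 h to 12 h.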

Compound 3, half-life: > 4 h
Compound 3 ended at the assay's limit; the forecaster's own chance of this, stated with the estimate: 85%; the middle value lies beyond the limit too.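

In this assay compound 3 gives > 4 h, a limit. No new step can be read among compound 1, compound 2 and compound 3: the limit of > 4 h in this assay, at which 3 of the 3 values shown sit. The compounds shown leave open whether half-life differs at all between trifluoromethyl, methoxy and chloro on this aromatic carbon.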